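Chain shortening and an ester terminus in an oxazole ketone series

The compounds below may be only part of what the source reports. "The series", "measured", "known", "first", "only" and "open" are said of these compounds alone.

Compound 1, `O=C(CCCCCCc1ccccc1C(=O)O)c1ncc(-c2ccccn2)o1`: > 600 nM
Compound 2, `O=C(CCCCCCc1cccnc1)c1ncc(-c2ccccn2)o1`: 32 nM
Compound 3, `CSc1cccc(CCCCCCC(=O)c2ncc(-c3ccccn3)o2)c1`: 4.2 nM

In an assay for inhibition of Fatty-acid amide hydrolase 1 (Rattus norvegicus) (a lower number here means a stronger inhibitor, a higher number a weaker inhibitor), compound 2 holds the higher of the two numbers read out directly, its nearest neighbour being compound 3 by a 7.6-fold lower number from compound 2 to compound 3 (0.88 log units; beyond the scatter). The value of compound 1 is a limit of the assay, not a number, as shown by the limit of > 600 nM in this assay, at which 1 of the 3 values shown sits.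

Compound 4, `COC(=O)CCCCC(=O)c1ncc(-c2ccccn2)o1`, differs from compound 2 by methoxycarbonyl in place of 2-(pyridin-3-yl)ethyl on a saturated chain carbon, four bonds along the chain from a carbonyl carbon. The measured steps all exchange the terminal ring group while the chain is kept: an at least 18-fold lower number from compound 1 to compound 2 (1.27 log units; beyond the scatter), an at least 140-fold lower number from compound 1 to compound 3 (2.15 log units; beyond the scatter) and a 7.6-fold lower number from compound 2 to compound 3 (0.88 log units; beyond the scatter). They show that the terminal group moves the number widely, but none of them shortens the chain or removes the ring, so they bear on this step only loosely. With the ring gone and the chain cut back, a weaker inhibitor is expected, the step being a 22-fold higher number from compound 2 to compound 4 (1.34 log units; beyond the scatter). For compound 4 the estimate in this assay is 700 nM, with a range from 100 nM to 5000 nM.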

Compound 4, inhibition constant: 1800 nM
Estimate against measurement, compound 4: 2.6-fold (0.41 log units) below; the measured number falls inside the stated range.
By their numbers in this assay, from the lowest: compound 3; then compound 2; then compound 4.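

In this assay, within the data shown here, the earlier steps exchanged only the terminal ring group on a chain that stayed the same, whereas methoxycarbonyl in place of 2-(pyridin-3-yl)ethyl removes the ring and cuts the chain back, giving a 56-fold higher number from compound 2 to compound 4 (1.75 log units; beyond the scatter) in a single change. Compound 4 still gives a measured number with no terminal ring at all, so a ring at this position is not needed for a reading in this assay, although the loss in inhibition is large. Nothing in the data at hand gives a cause for this step.

The loss of the ring and the shorter chain remain unseparated; pyridin-3-yl on the shorter chain, or methoxycarbonyl on the longer chain, would divide them. Going by these compounds, how a carboxylic acid or a primary amide in place of methoxycarbonyl would read on this chain also stays open.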